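Swapping methyl for a larger group on compound 2

The source may hold more compounds than are shown below. What is called first, only, known or untested is meant among the compounds shown, and "the series" means these compounds.

Measured in a functional assay on KB cells (Homo sapiens) for cytotoxicity, read by MTT assay, with a stated time of 3 days; on this read-out lower numbers stand for stronger inhibition and higher numbers for weaker inhibition:
Compound 1 `N#Cc1c(Nc2ccccn2)nc(SCc2nc3ccccc3[nH]2)nc1-c1ccccc1`: 7.35 nM
Compound 2 `CN1CCN(c2nc(SCc3nc4ccccc4[nH]3)nc(-c3ccccc3)c2C#N)CC1`: 2.7 nM

Of these two compounds, compound 2 has the lower number, 2.7 nM. Compound 3 `Cc1ccc(S(=O)(=O)N2CCN(c3nc(SCc4nc5ccccc5[nH]4)nc(-c4ccccc4)c3C#N)CC2)cc1` differs from it at one place, with (4-methylphenyl)sulfonyl in place of methyl on an amine nitrogen in a ring. Among the measured compounds shown here, no measured compound carries anything but methyl at that nitrogen, so the data give no direct guide. For the measured compounds named here, the only measured step is a 2.7-fold lower number from compound 1 to compound 2 (0.43 log units; beyond the scatter), a modest change made at another place. It shows that exchanging a whole group there moved the number only a little. A step of similar modest size is therefore expected in this assay, tentatively towards a higher number, and the direction remains uncertain. The expected change is a 1.9-fold higher number from compound 2 to compound 3 (0.27 log units; within the scatter). For compound 3 the estimated value is 5 nM, with an expected range of 1.2 nM to 22 nM.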

Compound 3, half-maximal inhibitory concentration: 3.28 nM
Estimate against measurement, compound 3: 1.5-fold (0.18 log units) above; low and high end bracket the measured number.
By their numbers in this assay, from the lowest: compounds 2 and 3 (each within the scatter of the next); then compound 1.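

In this assay, among the compounds shown here, the earlier compounds gave no comparison at the amine nitrogen in the ring, and the new pair supplies the first one: the step is a 1.2-fold higher number from compound 2 to compound 3 (0.08 log units; within the scatter) and leaves the two compounds indistinguishable on this read-out. The change is large in structure, as (4-methylphenyl)sulfonyl brings 10 heavy atoms, a six-membered aromatic ring and 2 hydrogen-bond acceptors where methyl held a single carbon, so at this position the number does not follow the size of the group in this pair. Nothing available explains why the number holds.

With only two groups shown at this nitrogen, it remains open whether the insensitivity is general. A bare amine hydrogen, an acetyl group, a carboxylic acid on a short chain or a longer alkyl chain might behave differently there.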